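Removing a Methoxy Group from a Styryl-Biaryl Core

The source may report more compounds than this note shows. Statements on the series, on what has been measured and on what is new or still open speak of the compounds shown alone.

Compound 1 `COc1ccc(/C=C/c2cc(OC)c(OC)c(OC)c2-c2ccc(OC)cc2)cc1` and compound 2 `COc1ccc(/C=C/c2cc(OC)c(OC)c(OC)c2-c2ccc(OC)c(OC)c2)cc1` share one core and differ in a single spot. In a functional assay on HeLa cells (Homo sapiens) for cytotoxicity, read by MTT assay, with a stated time of 48 h (a lower number here means a stronger inhibitor, a higher number a weaker inhibitor), compound 1 gives 19000 nM, while compound 2 gives 45000 nM. The change hydrogen in place of methoxy on an aromatic carbon produced a 2.4-fold lower number from compound 2 to compound 1 (0.37 log units; beyond the scatter). Compound 3 `C=C(c1ccc(OC)cc1)c1cc(OC)c(OC)c(OC)c1-c1ccccc1` has a different core; the difference between the two cores is not broken down here. In this assay compound 3 gives 11000 nM. Compound 4 `C=C(c1ccccc1)c1cc(OC)c(OC)c(OC)c1-c1ccccc1` is compound 3 after the change (hydrogen in place of methoxy on an aromatic carbon), the same kind of change as before, but at a place para to a large group rather than ortho to a methoxy group and meta to a large group. Because the earlier step of a 2.4-fold lower number from compound 2 to compound 1 (0.37 log units; beyond the scatter) was modest and the place differs, compound 4 is expected to show a 1.2-fold lower number from compound 3 to compound 4 (0.09 log units; within the scatter), with an estimated value of 9000 nM, between 3500 nM and 35000 nM.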

Compound 4, half-maximal inhibitory concentration: 42000 nM
For compound 4 the middle estimate is 4.7-fold (0.67 log units) below the measured one, outside the stated range (above it).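

Replacing methoxy with hydrogen does not carry over predictably between these two cores. In this assay, the change gives a 3.8-fold higher number from compound 3 to compound 4 (0.58 log units; beyond the scatter), so the number rises here, whereas it fell in the earlier pair. The two results point in opposite directions, and the gap between them is larger than repeat measurements would explain: the same change on two cores in this assay, a 2.4-fold lower number (0.37 log units; beyond the scatter) from compound 2 to compound 1 and a 3.8-fold higher number (0.58 log units; beyond the scatter) from compound 3 to compound 4, 9.0-fold (0.96 log units) apart, beyond the scatter of two such steps

This shows that one result cannot simply be transferred to the other core, but not what sets the direction, since the two pairs differ in both core and place of the change.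

On these data alone, it remains open whether the direction follows the core or the place when only one of them varies. As far as these compounds go, it is also open how a hydroxyl group, an amine or a fluorine atom at these places would behave on either core.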